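Working notes on the dichlorophenyl analogue in the series

The source may hold more compounds than are shown below. What is called first, only, known or untested is meant among the compounds shown, and "the series" means these compounds.

Compound 3 `O=C(/C=C\c1cccc(Cl)c1)N1N=C(c2ccncc2)OC1c1c[nH]c2ccccc12` is known in an ADME assay on A549 cells (Homo sapiens) for cytotoxicity, read by MTT assay, with a stated time of 48 h (on this read-out higher numbers stand for weaker inhibition of growth and lower numbers for stronger inhibition of growth), only as a limit of the assay: compound 3 gives > 30 ug/mL. Compound 1 `O=C(/C=C\c1cccc(F)c1)N1N=C(c2ccncc2)OC1c1c[nH]c2ccccc12` likewise reaches only a limit, giving > 30 ug/mL. Compound 2 `O=C(/C=C\c1ccccc1Cl)N1N=C(c2ccncc2)OC1c1c[nH]c2ccccc12` also stops at a limit, giving > 30 ug/mL. All three values therefore sit at the limit of > 30 ug/mL in this assay, at which 3 of the 3 values shown sit, and every step between measured compounds is left unreadable: a step that the two limits leave unreadable from compound 1 to compound 2, a step that the two limits leave unreadable from compound 1 to compound 3 and a step that the two limits leave unreadable from compound 2 to compound 3. Going by the values given here, nothing among the measured steps shows a change in growth inhibition on swapping one halogenated phenyl for another on this chain carbon.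

Compound 4 `O=C(/C=C\c1ccc(Cl)cc1Cl)N1N=C(c2ccncc2)OC1c1c[nH]c2ccccc12` differs from compound 3 by 2,4-dichlorophenyl in place of 3-chlorophenyl on a double-bonded chain carbon bound to a double-bonded chain carbon. The three unreadable steps are the only ones that bear on this change, so no size of step can be read from them; the expectation is that compound 4 remains at the limit, with a step that the limit leaves unreadable from compound 3 to compound 4 expected to be none beyond the scatter. Compound 4 is thus estimated at 40 ug/mL, within a range from 20 ug/mL to 100 ug/mL, most likely reported again as a limit.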

Compound 4, concentration for 50% growth inhibition: > 30 ug/mL
Compound 4: a limit, no number; the forecaster's own chance of this, stated with the estimate: 80%; the middle value does not contradict the limit.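

Compound 4 stops at a limit, as do compound 1, compound 2 and compound 3, so none of the steps among them can be read: the limit of > 30 ug/mL in this assay, at which 4 of the 4 values shown sit. The compounds shown leave open whether changing the halogens on the phenyl alters growth inhibition in this assay at all.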